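The compounds below may be only part of what the source reports. "The series", "measured", "known", "first", "only" and "open" are said of these compounds alone.

Measured so far:
compound 1, `CN(C)CCCCCSC1=Nc2ccccc2C(CC(=O)NCc2ccccc2)N1c1ccc(-c2ccccc2)cc1`, 76.2%
compound 2, `O=C(CC1c2ccccc2N=C(SCCCCCN2CCCC2)N1c1ccc(-c2ccccc2)cc1)NCc1ccccc1`, 93.9%

In an assay on cells for inhibition of Voltage-dependent T-type calcium channel subunit alpha-1G (Homo sapiens), read by patch clamp, tested at 10 uM (on this read-out higher numbers stand for more inhibition at the one concentration tested (going by the name of the read-out) and lower numbers for less inhibition), compound 1 gives 76.2% and stands lowest of the two numbers measured. Among the measured compounds shown here, the only measured step, a number 17.7 percentage points higher from compound 1 to compound 2 (beyond the scatter), is beyond the scatter but concerns the amine at the end of the saturated chain, five bonds along from the sulfur, and leaves the aromatic part of the core untouched.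

Compound 3, `CN(C)CCCCCSC1=Nc2ccccc2C(CC(=O)NCc2ccccc2)N1c1ccccc1`, has not yet been measured in this assay. It differs from compound 1 by hydrogen in place of phenyl on an aromatic carbon. For the measured compounds named here, no measured step touches this position, so the step from compound 1 to compound 2 gives no direct guide to it; it only shows that a single change elsewhere can move the read-out beyond the scatter. With an aromatic ring removed and no comparison to lean on, a downward step is expected, a number 21.2 percentage points lower from compound 1 to compound 3 (beyond the scatter), with wide uncertainty. Compound 3 is estimated at 55% in this assay, within a range from 20% to 85%.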

Compound 3, a percentage reported as inhibition, at one concentration (the size of the read-out at that concentration, not a potency): 46.5%
Beside the measured number, compound 3's estimate is 8.5 percentage points above it; measured number inside the range.
By their numbers in this assay, from the lowest: compound 3; then compound 1; then compound 2.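

Cutting 4-phenylphenyl back to phenyl gives a number 29.7 percentage points lower from compound 1 to compound 3 (beyond the scatter) in this assay, so the outer ring, on an aromatic carbon and para to a large group, has a clear bearing on this read-out at the one concentration tested. Among the compounds shown here, the series now has a change in the aromatic part that lowers the number, while the only earlier step, a number 17.7 percentage points higher from compound 1 to compound 2 (beyond the scatter), came from the amine at the far end of the chain and raised it. Removing these six carbons, which add no hydrogen-bond donors or acceptors and no net charge, therefore moves the read-out beyond the scatter, but no available measurement explains the drop.

Still open, going by these compounds, is whether the outer phenyl itself matters or whether a smaller or different group at this place, such as a chlorine atom, a methoxy group or a pyridine ring, would restore the inhibition. It is also unclear whether the pyrrolidin-1-yl step carries over to the phenyl compound, since the two changes have been read only separately against the dimethylamino compound with 4-phenylphenyl, and a piperidine at the chain end would test how far that amine step extends.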